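Chloro on the pendant phenyl: a small step, twice

The compounds below may be only part of what the source reports. "The series", "measured", "known", "first", "only" and "open" are said of these compounds alone.

Three compounds of one series carry the same acylhydrazide-linked quinazolinone side and differ in the heteroaryl head. Compound 1 `O=C(CSc1nc(-c2ccccc2)c(C(=O)O)c(=O)[nH]1)Nn1c(COc2ccc(Cl)cc2Cl)nc2ccccc2c1=O` is measured in a functional assay on the whole organism (strain albino) for inhibition, with Rattus norvegicus as the target, read by paw edema, with stated times of 1 h and 0.5 h, at a dose of 100 mg/kg by the oral route (a higher number here means more inhibition at the dose given (going by the name of the read-out), a lower number less inhibition), and gives 61.5%. Compound 2 `O=C(CSc1nc(-c2ccc(Cl)cc2)c(C(=O)O)c(=O)[nH]1)Nn1c(COc2ccc(Cl)cc2Cl)nc2ccccc2c1=O` differs from it by chloro in place of hydrogen on an aromatic carbon, and in this assay compound 2 gives 51.9%. Among the measured compounds shown here, the resulting step of a number 9.6 percentage points lower from compound 1 to compound 2 (within the scatter) is the only measured instance of this change in the set. Compound 3 `N#Cc1c(Nc2ccccc2)nc(SCC(=O)Nn2c(COc3ccc(Cl)cc3Cl)nc3ccccc3c2=O)nc1-c1ccc(Cl)cc1` has a different core; the difference between the core of compound 1 and the core of compound 3 is not broken down here. In this assay compound 3 gives 36.5%, the lowest of the three numbers, separated from compound 2 and from compound 1 by gaps beyond the scatter.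

Compound 4 `N#Cc1c(Nc2ccc(Cl)cc2)nc(SCC(=O)Nn2c(COc3ccc(Cl)cc3Cl)nc3ccccc3c2=O)nc1-c1ccc(Cl)cc1` is not yet measured. It differs from compound 3 by chloro in place of hydrogen on an aromatic carbon, the same change as from compound 1 to compound 2 in the same kind of place, though cut one bond further out it reads anilino to (4-chlorophenyl)amino rather than phenyl to 4-chlorophenyl. Compound 4 is expected to show a step of a number 6.5 percentage points lower from compound 3 to compound 4 (within the scatter), of about the same small size as the earlier step, because a number 9.6 percentage points lower from compound 1 to compound 2 (within the scatter) lay within the scatter. On that basis compound 4 is estimated at 30% in this assay, with a range from 18% to 42% expected.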

Compound 4, a percentage reported as inhibition, in the whole organism at one dose (the size of the read-out at that dose, not a potency): 46.2%
Beside the measured number, compound 4's estimate is 16.2 percentage points below it; measured number above the stated range.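

In this assay, chloro in place of hydrogen on an aromatic carbon does not carry over from one core to the other as a single fixed step: the same change on two cores in this assay, a number 9.6 percentage points lower (within the scatter) from compound 1 to compound 2 and a number 9.7 percentage points higher (within the scatter) from compound 3 to compound 4, 19.3 percentage points apart, beyond the scatter of two such steps. The new step reads a number 9.7 percentage points higher from compound 3 to compound 4 (within the scatter) and, taken alone, does not separate the two compounds, so the result lies in the gap between the two steps and not in either step by itself. This does not show that the core alone sets the outcome: the change reads phenyl to 4-chlorophenyl in one pair and anilino to (4-chlorophenyl)amino in the other, the two cores differ in more than one place, and two pairs at a single dose give neither a cause nor a rule for the wider series.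

The compounds shown leave open whether chloro on the phenyl of the core of compound 1 and chloro on the anilino ring of the core of compound 3 would give opposite steps again if a second pair stood on each core. They also leave open whether fluoro or methoxy in place of the same hydrogen would follow chloro, or whether a methyl ester in place of the carboxylic acid of compound 1 would alter the step.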